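Aryl swap from compound 3 to compound 4

This account rests on a few compounds, and the source may have more. Where it says the series, first, only, none or still open, it means among the compounds named here.

Values in a functional assay on A549 cells (Homo sapiens) for inhibition, read by MTT assay, with a stated time of 72 h; on this read-out higher numbers stand for weaker inhibition and lower numbers for stronger inhibition:
compound 1 `O=C1/C(=C\c2ccccc2)c2c(ncn2COCc2ccccc2)CCN1Cc1ccccc1` gives 9900 nM
compound 2 `Cc1cc(C)cc(CN2CCc3ncn(COCc4ccccc4)c3/C(=C/c3ccccc3)C2=O)c1` gives 22500 nM
compound 3 `O=C1/C(=C\c2ccccc2)c2c(ncn2COCc2ccccc2)CCN1Cc1ccc(Cl)cc1` gives 11800 nM

The number for compound 3 lies inside the span set by compound 1 and compound 2, within the scatter of each. Still unmeasured is compound 4 `Cc1ccccc1CN1CCc2ncn(COCc3ccccc3)c2/C(=C/c2ccccc2)C1=O`, which keeps the shared core and differs from compound 3 by one group: 2-methylphenyl in place of 4-chlorophenyl on a saturated chain carbon bound to an amide-type nitrogen in a ring. In words, 2-methylphenyl stands in place of 4-chlorophenyl on a saturated chain carbon bound to an amide-type nitrogen in a ring.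

Going by the values given here, three measured steps touch this same group. The chloro step gave a 1.2-fold higher number from compound 1 to compound 3 (0.08 log units; within the scatter), which stays inside the scatter. The change to 3,5-dimethylphenyl gave a 2.3-fold higher number from compound 1 to compound 2 (0.36 log units; beyond the scatter), a modest move beyond the scatter. The remaining step, a 1.9-fold lower number from compound 2 to compound 3 (0.28 log units; within the scatter), stays inside the scatter. Among the compounds with values here, no measured compound carries 2-methylphenyl, so these steps serve only as a guide to size. Within the data shown here, the one step beyond the scatter points, at most, to a slight tilt towards a higher number. In this assay the expected change is a 1.1-fold higher number from compound 3 to compound 4 (0.06 log units; within the scatter), which means no step beyond the scatter. For compound 4 the estimated value is 13500 nM, with an expected range of 7500 nM to 24000 nM.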

Compound 4, half-maximal inhibitory concentration: 25600 nM
For compound 4 the middle estimate is 1.9-fold (0.28 log units) below the measured one, outside the stated range (above it).
By their numbers in this assay, from the lowest: compounds 1, 3, 2 and 4 (each within the scatter of the next, the first and the last beyond it).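

In this assay, the methyl step lies beyond the scatter (a 2.6-fold higher number from compound 1 to compound 4 (0.41 log units; beyond the scatter)), while the chloro step stays within it (a 1.2-fold higher number from compound 1 to compound 3 (0.08 log units; within the scatter)), so a single added group at this position can now be seen to move the number. The swap of 4-chlorophenyl for 2-methylphenyl also lies beyond the scatter (a 2.2-fold higher number from compound 3 to compound 4 (0.34 log units; beyond the scatter)), whereas 2-methylphenyl and 3,5-dimethylphenyl cannot be told apart (a 1.1-fold higher number from compound 2 to compound 4 (0.06 log units; within the scatter)); among these four compounds, both methyl-bearing aryl groups stand at higher numbers than phenyl, and no listed compound goes against this, though 4-chlorophenyl stays within the scatter of phenyl. Nothing available here accounts for the gap between the methyl-bearing and chloro-bearing compounds.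

On these data alone, whether the higher number follows the methyl group itself or its place on the ring remains open, and 4-methylphenyl and 2-chlorophenyl would be the compounds to separate the two. As far as these compounds go, it is also open how this position responds to a group of a different kind, such as a pyridyl ring, an amine or a carboxylic acid on the aryl group.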